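Shortening the Chain of Compound 1

The source may hold more compounds than are shown below. What is called first, only, known or untested is meant among the compounds shown, and "the series" means these compounds.

- compound 1 `Nc1nc2cc(-c3nn(CCCC(=O)NO)c4ncnc(N)c34)ccc2o1`: 19500 nM
- compound 2 `Nc1ncnc2c1c(-c1cnc3[nH]ccc3c1)nn2CCCCC(=O)NO`: > 50000 nM (a limit, not a number)
- compound 3 `Nc1ncnc2c1c(-c1cnc3[nH]ccc3c1)nn2CCCCCCC(=O)NO`: 37700 nM

All three compounds were tested in a functional assay on MDA-MB-231 cells (Homo sapiens) for inhibition, read by MTT assay, with a stated time of 72 h; on this read-out higher numbers stand for weaker inhibition and lower numbers for stronger inhibition. Only compound 1 and compound 3 give actual numbers, and these two lie within the usual scatter of each other. Compound 2 reaches only a limit of the assay.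

Compound 4 `Nc1nc2cc(-c3nn(CC(=O)NO)c4ncnc(N)c34)ccc2o1` is not yet measured. It keeps the core of compound 1 and places hydroxycarbamoyl where 2-(hydroxycarbamoyl)ethyl stood, on a saturated chain carbon bound to an aromatic nitrogen: hydroxycarbamoyl in place of 2-(hydroxycarbamoyl)ethyl on a saturated chain carbon bound to an aromatic nitrogen.

Within the data shown here, the only measured change in chain length is an at least 1.3-fold lower number from compound 2 to compound 3 (0.12 log units; that floor lies within the scatter). That step lengthens the chain rather than shortening it, sits on a different core and stays within the scatter, so it offers only weak guidance. Read in reverse, it hints at a small move toward a higher number in this assay, probably not beyond the scatter. The expected step is a 1.5-fold higher number from compound 1 to compound 4 (0.19 log units; within the scatter). For compound 4 the estimated value is 30000 nM, with an expected range of 13000 nM to 70000 nM.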

Compound 4, half-maximal inhibitory concentration: 6310 nM
Compound 4: the middle estimate sits 4.8-fold (0.68 log units) above what was measured; measured number outside the range, below it.
By their numbers in this assay, from the lowest: compound 4; then compounds 1 and 3 (each within the scatter of the next). At a limit, above all of these: compound 2.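

On the core of compound 1, the shorter chain gives stronger inhibition in this assay: hydroxycarbamoyl in place of 2-(hydroxycarbamoyl)ethyl on a saturated chain carbon bound to an aromatic nitrogen gives a 3.1-fold lower number from compound 1 to compound 4 (0.49 log units; beyond the scatter), so this position responds to chain length on this core. This is the first chain change shown that moves the number beyond the scatter, as the earlier step between compound 2 and compound 3 did not. A change in chain length also does not carry over unchanged from one core to the other, and the two steps differ clearly: the same change on two cores in this assay, an at least 1.3-fold lower number (0.12 log units; that floor lies within the scatter) from compound 2 to compound 3 and a 3.1-fold higher number (0.49 log units; beyond the scatter) from compound 4 to compound 1, at least 4.0-fold (0.61 log units) apart, beyond the scatter of two such steps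

Going by these compounds, with only these two chains on the core of compound 1, it remains open whether a longer chain would continue the same direction. On these data alone, it is also open how a carboxylic acid in place of the hydroxycarbamoyl would read on this shortest chain.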